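The compounds below may be only part of what the source reports. "The series", "measured", "known", "first", "only" and "open" are said of these compounds alone.

Compound 1 `Cn1c(N2CCCC2)c(C#N)c2c(N)ncnc21`: 41 nM
Compound 2 `Cn1c(-c2ccccc2)c(C#N)c2c(N)ncnc21`: 30 nM
Compound 3 `C[C@H]1CCCN1c1c(C#N)c2c(N)ncnc2n1C`: 136 nM

In an assay on isolated protein for binding affinity to Leucine-rich repeat serine/threonine-protein kinase 2 (Homo sapiens), read by TR-FRET and LanthaScreen, with a stated time of 2 h (a lower number here means a stronger inhibitor, a higher number a weaker inhibitor), compound 3 stands at the highest of the three numbers: the step of a 3.3-fold higher number from compound 1 to compound 3 (0.52 log units; beyond the scatter) and the step of a 4.5-fold higher number from compound 2 to compound 3 (0.66 log units; beyond the scatter) both lie beyond the scatter, whereas a 1.4-fold lower number from compound 1 to compound 2 (0.14 log units; within the scatter) does not. Compound 4 `Cn1c(N)c(C#N)c2c(N)ncnc21` differs from compound 3 by amino in place of 2-methylpyrrolidin-1-yl on an aromatic carbon. For the measured compounds named here, no measured step replaces the whole ring with amino, so the two modest steps that lead into compound 3 are the only guide; they show that this position moves the number, but not which way a much smaller group will take it. The estimate for compound 4 is therefore wide: it is expected near 120 nM, between 30 nM and 500 nM, which means an expected step of a 1.1-fold lower number from compound 3 to compound 4 (0.05 log units; within the scatter).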

Compound 4, inhibition constant: 346 nM
Compound 4: middle estimate off by 2.9-fold (0.46 log units), on the low side; the range from low to high includes it.
By their numbers in this assay, from the lowest: compounds 2 and 1 (each within the scatter of the next); then compound 3; then compound 4.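

With amino on this aromatic carbon the number rises in every comparison: a 2.5-fold higher number from compound 3 to compound 4 (0.41 log units; beyond the scatter) and an 8.4-fold higher number from compound 1 to compound 4 (0.93 log units; beyond the scatter) and a 12-fold higher number from compound 2 to compound 4 (1.06 log units; beyond the scatter) all lie beyond the scatter. The earlier compounds shown here showed only that this position moves the number, whereas compound 4 shows the direction this small group takes it, away from the values of the ring-bearing compounds. Nothing measured here explains this change. The compounds shown leave open whether a dimethylamino group, a methylamino group or an open chain such as butyl would keep the number nearer that of compound 1. They also leave open whether a ring is needed at all.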